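A few compounds are considered here, and "the series" means these few. Any claim that something is new, unique, unknown or untested is made for them only; others in the source may bear on it.

Measured so far (in an ADME assay on MRC5 cells (Homo sapiens), read by MTT assay, with a stated time of 72 h; on this read-out higher numbers stand for weaker inhibition and lower numbers for stronger inhibition)
- Compound 1 `CNc1ncnc2c1c(-c1ccsc1)cn2[C@@H]1O[C@H](CO)[C@@H](O)[C@H]1O` gives > 100000 nM as a limit of the assay
- Compound 2 `Cc1ncnc2c1c(-c1ccoc1)cn2[C@@H]1O[C@H](CO)[C@@H](O)[C@H]1O` gives 98300 nM as a number

For the measured compounds named here, compound 2 holds the only true number in this small set, reading 98300 nM in this assay at the weak end of inhibition. The reading for compound 1 is a limit and not a number (the limit of > 100000 nM in this assay, at which 1 of the 2 values shown sits).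

Compound 3 `Cc1ncnc2c1c(-c1ccsc1)cn2[C@@H]1O[C@H](CO)[C@@H](O)[C@H]1O` has not yet been measured. It carries thiophen-3-yl in place of furan-3-yl on an aromatic carbon of a five-membered aromatic ring with 1 nitrogen (thiophen-3-yl in place of furan-3-yl on an aromatic carbon). Going by the values given here, no measured pair here shows what this exchange does, so the expectation rests on compound 2 at 98300 nM as its starting point. In this assay only a small step is expected, probably none beyond the usual scatter, with any movement leaning towards stronger inhibition. The estimate amounts to a 1.4-fold lower number from compound 2 to compound 3 (0.15 log units; within the scatter) as the expected step. Compound 3 is expected at 70000 nM with an estimated range from 20000 nM to 100000 nM in this read-out.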

Compound 3, half-maximal inhibitory concentration: > 100000 nM
Compound 3: no number, only a limit (the forecaster's own chance of this, stated with the estimate: 40%); middle value at least 1.4-fold (0.15 log units) away from the limit.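

In this assay compound 3 gives > 100000 nM, which is a limit of the assay and not a number. Thiophen-3-yl in place of furan-3-yl on this aromatic carbon gives an at least 1.0-fold higher number from compound 2 to compound 3 (0.00 log units; that floor lies within the scatter), so the exchange shows no sign of stronger inhibition, although the true size of the step stays unknown. The step for methyl in place of methylamino on an aromatic carbon cannot be read, and the values now gather at one end of the scale: the limit of > 100000 nM in this assay, at which 2 of the 3 values shown sit.

The compounds shown leave open how far the true values of compound 1 and compound 3 lie beyond their limits, and so whether the exchange of furan-3-yl for thiophen-3-yl has an effect larger than the scatter. Also open, on these data alone, is whether a different kind of group on this aromatic carbon, such as an amine or a carboxylic acid in place of the five-membered aromatic ring, would bring a true number well away from that limit in this assay.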